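Three Quaternary Pyridinium and Piperidinium Ketones Compared for Solubility

This account rests on a few compounds, and the source may have more. Where it says the series, first, only, none or still open, it means among the compounds named here.

The measured compounds and their values:
compound 1, `COc1cc2cc(C(=O)CC3=CC[N+](C)(Cc4ccccc4)CC3)sc2cc1OC`, 20000 ug/mL;
compound 2, `COc1cc2cc(C(=O)CCC3CC[N+](C)(CC(=O)OC(C)(C)C)CC3)sc2cc1OC`, 1500 ug/mL;
compound 3, `COc1cc2cc(C(=O)CCc3cc[n+](C)cc3)sc2cc1OC`, 3000 ug/mL.

All three share the same dimethoxy-substituted bicyclic ketone core and differ in the charged ring attached through the short linker. In a physicochemical assay for solubility (on this read-out higher numbers stand for higher solubility and lower numbers for lower solubility), compound 1 gives 20000 ug/mL, the highest number of the three. Compound 2 gives 1500 ug/mL and compound 3 gives 3000 ug/mL. Compound 3 thus stands second of the three numbers: its gap to compound 2 lies within the scatter, so no order between them can be read, while its gap to compound 1 is beyond the scatter, with compound 1 the higher.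

Compound 4, `CCC[n+]1ccc(CCC(=O)c2cc3cc(OC)c(OC)cc3s2)cc1`, has not yet been measured. It differs from compound 3 by ethyl in place of hydrogen on a saturated chain carbon bound to an aromatic nitrogen. Going by the values given here, no pair of measured compounds differs in one place only, so no measured step can be drawn on; the three compounds all carry different substituents on the charged nitrogen, and among them the change from a small group to a larger one shows no single direction.

For compound 4 in this assay a modest lowering of the number is expected, of a size a 1.5-fold lower number from compound 3 to compound 4 (0.18 log units; within the scatter) that stays close to the scatter. Compound 4 is estimated at 2000 ug/mL, with a range from 700 ug/mL to 6000 ug/mL.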

Compound 4, solubility: 16000 ug/mL
Compound 4: middle estimate off by 8.0-fold (0.90 log units), on the low side; the whole stated range lies below it.
By their numbers in this assay, from the lowest: compounds 2 and 3 (each within the scatter of the next); then compounds 4 and 1 (each within the scatter of the next).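

In this assay, ethyl in place of hydrogen on a saturated chain carbon bound to an aromatic nitrogen gives a 5.3-fold higher number from compound 3 to compound 4 (0.73 log units; beyond the scatter), a step beyond the scatter; the same difference, cut one bond further out, reads methyl to propyl. Going by these compounds alone, this is the first change in one place alone in the set, and it shows that the number responds to this position and, for this single pair, moves upward, which the earlier compounds could not show because each differed from the others in more than one place. No measurement shown here accounts for the size or the direction of this step.

Going by these compounds, a single step sets no trend, so it remains open whether a butyl or hexyl chain at this place would carry the number further up, hold it or bring it back down, and whether an ethyl chain would fall on the way from methyl to propyl. On these data alone, it also remains open how a chain ending in a carboxylic acid or an amine would behave at this place, and whether the same change would give a similar step on the charged rings of compound 1 and compound 2.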